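Five-membered heteroaryl substituents on the shared core: maximal response

The source may hold more compounds than are shown below. What is called first, only, known or untested is meant among the compounds shown, and "the series" means these compounds.

Measured so far in a functional assay with Alpha-1B adrenergic receptor (Homo sapiens) as the target, read by calcium flux; a higher number here means a larger maximal response, a lower number a smaller maximal response:
compound 1 `Cn1cc(-c2ccccc2NCC2=NCCN2)cn1` gives 0%
compound 2 `Cn1ncnc1-c1ccccc1NCC1=NCCN1` gives 93%
compound 3 `c1ccc(-c2cn[nH]c2)c(NCC2=NCCN2)c1` gives 72%

Compound 3 stands second highest of the three numbers. Its nearest neighbour is compound 2, the step of a number 21 percentage points lower from compound 2 to compound 3 (beyond the scatter); its furthest is compound 1, the step of a number 72 percentage points higher from compound 1 to compound 3 (beyond the scatter). The largest step in the set is a number 93 percentage points higher from compound 1 to compound 2 (beyond the scatter).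

Next in line is compound 4 `c1ccc(-c2nc[nH]n2)c(NCC2=NCCN2)c1`. It differs from compound 3 in one place:
1H-1,2,4-triazol-3-yl in place of 1H-pyrazol-4-yl on an aromatic carbon

For the measured compounds named here, two measured steps bear on this change. The step of a number 21 percentage points lower from compound 2 to compound 3 (beyond the scatter) shows the move from a 1,2,4-triazolyl to a pyrazol-4-yl group on that carbon costing a modest amount, and the step of a number 72 percentage points higher from compound 1 to compound 3 (beyond the scatter) shows that the free ring nitrogen hydrogen, as in compound 3 and compound 4, goes with a large response. Compound 4 carries both a 1,2,4-triazolyl ring and the free ring nitrogen hydrogen, so the expectation is a response at or somewhat above that of compound 3, with no clear case for a drop beyond the scatter.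

For compound 4 in this assay, the estimated value is 80%, within a range of 45% to 100%, which would mean an expected step of a number 8 percentage points higher from compound 3 to compound 4 (within the scatter).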

Compound 4, largest response reached (reported as maximal response), in percent of the reference or control that the assay uses: 100%
Estimate against measurement, compound 4: 20 percentage points below; measured number inside the range.
By their numbers in this assay, from the lowest: compound 1; then compound 3; then compounds 2 and 4 (each within the scatter of the next).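

Replacing 1H-pyrazol-4-yl with 1H-1,2,4-triazol-3-yl on the aromatic carbon gives a number 28 percentage points higher from compound 3 to compound 4 (beyond the scatter) in this assay, so with the ring hydrogen-bond donor kept, the two five-membered rings are not interchangeable, although they differ in the count of ring nitrogens and hydrogen-bond acceptors and not in heavy atoms. The step from the methylated triazole is a number 7 percentage points higher from compound 2 to compound 4 (within the scatter), so within this triazole pair, which also differs in ring attachment, the free ring hydrogen is not needed for a large response, whereas a number 72 percentage points higher from compound 1 to compound 3 (beyond the scatter) marks a large gain in the pyrazole pair, and a number 100 percentage points higher from compound 1 to compound 4 (beyond the scatter) spans the whole range of the set. No measurement accompanies these numbers that would account for them.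

A 1H-pyrazol-3-yl group would help separate the point of ring attachment from the number of ring nitrogens, which these compounds change together. As far as these compounds go, how a tetrazol-5-yl ring, a carboxylic acid or an aminomethyl group on this carbon would behave remains open, as does whether the response can be kept with a six-membered ring such as pyridyl.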